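The compounds below may be only part of what the source reports. "The series", "measured", "known", "first", "only" and "open" are said of these compounds alone.

In an assay on isolated protein for inhibition of thyroid hormone receptor beta (Homo sapiens), read by fluorescence, with a stated time of 30 min (on this read-out lower numbers stand for stronger inhibition and higher numbers for weaker inhibition), compound 3 `COc1cc(C(=O)N2CCC(O)CC2)cc2nc(NCc3cccc(Cl)c3)oc12` gives 352 nM, the highest number among the three measured compounds; compound 1 `COc1cc(C(=O)N2CCCC2)cc2nc(NCc3cccc(Cl)c3)oc12` gives 180 nM and compound 2 `COc1cc(C(=O)N2CCC(C)(C)C2)cc2nc(NCc3cccc(Cl)c3)oc12` gives 40 nM. Compound 4 `COc1cc(C(=O)N2CC[C@@H](O)C(C)(C)C2)cc2nc(NCc3cccc(Cl)c3)oc12` differs from compound 3 by 4-hydroxy-3,3-dimethylpiperidin-1-yl in place of 4-hydroxypiperidin-1-yl on a carbonyl carbon. The step that bears most directly on this change is a 4.5-fold lower number from compound 1 to compound 2 (0.65 log units; beyond the scatter), where dimethyl substitution was likewise introduced on the amide ring, while a 2.0-fold higher number from compound 1 to compound 3 (0.29 log units; within the scatter) and an 8.8-fold higher number from compound 2 to compound 3 (0.94 log units; beyond the scatter) place compound 3 relative to its neighbours. A drop of comparable size is therefore expected in this assay, which would mean a 3.9-fold lower number from compound 3 to compound 4 (0.59 log units; beyond the scatter). Compound 4 is accordingly estimated at 90 nM, within a range from 35 nM to 250 nM.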

Compound 4, half-maximal inhibitory concentration: 35 nM
Compound 4: the middle estimate sits 2.6-fold (0.41 log units) above what was measured, and the stated range covers the measured number.
By their numbers in this assay, from the lowest: compounds 4 and 2 (each within the scatter of the next); then compounds 1 and 3 (each within the scatter of the next).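

In this assay, the dimethyl substitution also lowers the number on the six-membered hydroxy-bearing ring, with a 10-fold lower number from compound 3 to compound 4 (1.00 log units; beyond the scatter), so the earlier gain on the pyrrolidine ring is now matched by a gain on a second amide ring. The new group cannot be told apart from 3,3-dimethylpyrrolidin-1-yl, with a 1.1-fold lower number from compound 2 to compound 4 (0.06 log units; within the scatter), yet it stands clear of pyrrolidin-1-yl, with a 5.1-fold lower number from compound 1 to compound 4 (0.71 log units; beyond the scatter). No supporting data account for this gain. Open questions are how the opposite configuration at the defined stereocentre of compound 4 would read and whether an amine or a methoxy group could replace the hydroxyl group.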